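Chloro in Place of Hydrogen on an Ester of the Shared Core

A few compounds are considered here, and "the series" means these few. Any claim that something is new, unique, unknown or untested is made for them only; others in the source may bear on it.

Measured compounds:
compound 1, `O=C(OCc1ccccc1)c1coc(-c2ccccc2)n1`: 1.8%
compound 2, `O=C(Oc1c(Cl)cc(Cl)cc1Cl)c1coc(-c2ccccc2)n1`: 1.3%
compound 3, `O=C(Oc1ccc(Cl)cc1Cl)c1coc(-c2ccccc2)n1`: 0.8%

Three esters of one core have been measured in a physicochemical assay for metabolic stability, read by LC-MS, in simulated gastric fluid, with a stated time of 15 min, tested at 50 uM; on this read-out higher numbers stand for a more stable compound and lower numbers for a less stable compound. Compound 1 stands alongside compound 2 and compound 3 without any of the three being set apart, as the gap between compound 1 and each of the others lies within the scatter. The difference between the core of compound 1 and that of compound 3 is not broken down here. From compound 3 to compound 2 the change is chloro in place of hydrogen on an aromatic carbon, and the step it made was a number 0.5 percentage points higher from compound 3 to compound 2 (within the scatter).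

Compound 4, `O=C(OCc1ccccc1)c1coc(-c2ccccc2Cl)n1`, has not yet been measured. It differs from compound 1 by chloro in place of hydrogen on an aromatic carbon. This is the same kind of change as that from compound 3 to compound 2, though the surroundings differ: in compound 2 the new chloro sits meta to two chloro groups, whereas in compound 4 it does not. Because a number 0.5 percentage points higher from compound 3 to compound 2 (within the scatter) stayed within the scatter, a step from compound 1 to compound 4 of about a number 0.2 percentage points higher from compound 1 to compound 4 (within the scatter) is expected. Compound 4 is therefore estimated at 2%, between 0.5% and 6%.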

Compound 4, percent of the compound remaining: 1.1%
For compound 4 the middle estimate is 0.9 percentage points above the measured one; measured number inside the range.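

In this assay, chloro in place of hydrogen on an aromatic carbon gave a number 0.7 percentage points lower from compound 1 to compound 4 (within the scatter) and, on the other pair of esters, a number 0.5 percentage points higher from compound 3 to compound 2 (within the scatter). Both steps lie within the scatter, so neither pair shows a real effect of this change on stability. That is all the two pairs show: they do not establish that the change behaves alike on both cores, or that it would stay this small on another core, and no measurement here explains the result.

The compounds shown leave open what a different group at this aromatic carbon, such as an amine or a carboxylic acid, would do. They also leave open whether an amide in place of the ester would change the stability.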